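A few compounds are considered here, and "the series" means these few. Any claim that something is new, unique, unknown or untested is made for them only; others in the source may bear on it.

Measured compounds in an ADME assay on PLP2 cells (Sus scrofa) for inhibition, read by sulforhodamine B assay, with a stated time of 48 h; on this read-out higher numbers stand for weaker inhibition of growth and lower numbers for stronger inhibition of growth:
- compound 2 `COc1cccc(Oc2ccnc3ccsc23)c1` gives 26700 nM
- compound 3 `Fc1ccccc1Oc1ccnc2ccsc12` gives 87200 nM
- compound 1 `Fc1ccc(Oc2ccnc3ccsc23)cc1` is reported only as a limit, > 125000 nM

Among the numbers actually obtained in this assay , compound 2 stands lowest; the nearest of these is compound 3, whose number is higher by a margin beyond the usual scatter. The value of compound 1 is a limit of the assay, as recorded in the limit of > 125000 nM in this assay, at which 1 of the 3 values shown sits, and not a number.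

The next compound, compound 4 `Fc1cccc(Oc2ccnc3ccsc23)c1`, has not yet been measured in this assay . It differs from compound 2 in one place: fluoro in place of methoxy on an aromatic carbon, the fluoro sitting on an aromatic carbon of a six-membered aromatic ring of carbon only, meta to a large group. Going by the values given here, no pair of measured compounds shares exactly this change, so the size of the step must be estimated from what is known. Given that the two fluoro-bearing compounds, compound 3 and compound 1, sit at higher numbers than compound 2, compound 4 is expected to follow the same tendency, with an estimated step from compound 2 to compound 4 of a 2.6-fold higher number from compound 2 to compound 4 (0.42 log units; beyond the scatter), towards weaker inhibition of growth. Compound 4 is therefore estimated at 70000 nM, with a likely range from 25000 nM to 160000 nM.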

Compound 4, concentration for 50% growth inhibition: > 125000 nM
Compound 4 was reported as a limit; the forecaster's own chance of this, stated with the estimate: 25%; middle value at least 1.7-fold (0.25 log units) from the limit.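

In this assay, the change from methoxy to fluoro on this aromatic carbon, meta to a large group, now has a step of its own, pointing towards weaker inhibition of growth: an at least 4.6-fold higher number from compound 2 to compound 4 (0.67 log units; beyond the scatter). Compound 4 is reported only as a limit, > 125000 nM, and not as a number. The step is therefore bounded from one side only, and its true size cannot be read, because the values end at a limit: the limit of > 125000 nM in this assay, at which 2 of the 4 values shown sit.

The compounds shown leave open whether an amine, a hydroxy group or a longer ether chain at this place would keep the number of compound 2 or lose it as fluoro does. Going by these compounds, they also hold methoxy at this one place only, so what methoxy does elsewhere on the aromatic ring remains unknown.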